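This account rests on a few compounds, and the source may have more. Where it says the series, first, only, none or still open, it means among the compounds named here.

Compound 1 `Nc1nc(-c2ccco2)nc2sc(CN3CCC(F)CC3)cc12` is the reference point of this short set. In an assay on CHO-K1 cells for antagonist activity at adenosine receptor A1 (Homo sapiens), read by a beta-galactosidase reporter, with stated times of 15 min and 6 h (on this read-out lower numbers stand for stronger inhibition and higher numbers for weaker inhibition), compound 1 gives 740 nM, the lowest of the three numbers recorded. Compound 2 `Nc1nc(-c2ccco2)nc2sc(CN3CCC(O)CC3)cc12` gives 4000 nM in this assay, and compound 3 `Nc1nc(-c2ccco2)nc2sc(CN3CCC(=O)CC3)cc12` gives 2720 nM. The steps away from compound 1 are both beyond the scatter: a 5.4-fold higher number from compound 1 to compound 2 (0.73 log units; beyond the scatter) and a 3.7-fold higher number from compound 1 to compound 3 (0.57 log units; beyond the scatter), while a 1.5-fold lower number from compound 2 to compound 3 (0.17 log units; within the scatter) stays within the scatter. All three measured steps concern only the group carried on the piperidine ring.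

Compound 4 `Nc1nc(-c2ccc(Cl)o2)nc2sc(CN3CCC(F)CC3)cc12` differs from compound 1 at a different place altogether: chloro in place of hydrogen on an aromatic carbon, that is, on an aromatic carbon of a five-membered aromatic ring with one oxygen, next to the ring oxygen, so that the furan-2-yl becomes 5-chlorofuran-2-yl. Within the data shown here, no measured step in this set touches that ring, so none of the three steps bears directly on the change, and the data give no direction for it. The expectation for compound 4 in this assay is therefore a step of a 1.2-fold lower number from compound 1 to compound 4 (0.09 log units; within the scatter), which is not beyond the scatter. Compound 4 is estimated at 600 nM in this assay, with a range from 150 nM to 2500 nM to reflect the absence of a comparable step.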

Compound 4, inhibition constant: 1080 nM
Compound 4: the middle estimate sits 1.8-fold (0.26 log units) below what was measured; low and high end bracket the measured number.
By their numbers in this assay, from the lowest: compounds 1 and 4 (each within the scatter of the next); then compounds 3 and 2 (each within the scatter of the next).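

Among these compounds, the chloro group in compound 4 is the first change in this set away from the piperidine ring, and in this assay it shows that hydrogen can give way to chloro on this aromatic carbon, next to the ring oxygen, with a 1.5-fold higher number from compound 1 to compound 4 (0.16 log units; within the scatter). That step stays within the scatter, so the change from furan-2-yl to 5-chlorofuran-2-yl leaves the number in place, whereas the piperidine changes gave a 5.4-fold higher number from compound 1 to compound 2 (0.73 log units; beyond the scatter) and a 3.7-fold higher number from compound 1 to compound 3 (0.57 log units; beyond the scatter), both beyond the scatter. Nothing available accounts for this outcome at the furan position.

The compounds shown leave open whether this position would tolerate a group other than chloro, such as bromo, methyl, an amine or a carboxylic acid, and whether any of these would move the number beyond the scatter. They also leave open whether 5-chlorofuran-2-yl would give a similar result alongside 4-hydroxypiperidin-1-yl or 4-oxopiperidin-1-yl, the groups carried by compound 2 and compound 3, since it appears here only with the 4-fluoropiperidin-1-yl group.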